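Aryl replacements on the shared core: notes toward compound 4

A few compounds are considered here, and "the series" means these few. Any claim that something is new, unique, unknown or untested is made for them only; others in the source may bear on it.

Measured in a functional assay on U-251 cells (Homo sapiens) for inhibition, read by sulforhodamine B assay, with a stated time of 48 h; a lower number here means a stronger inhibitor of growth, a higher number a weaker inhibitor of growth:
compound 1 `COc1ccc(/C=N/NC(=S)NC(C)(C)[C@H]2CC=C(C)CC2)cc1` gives 11400 nM
compound 2 `CC1=CC[C@H](C(C)(C)NC(=S)N/N=C/c2ccccc2O)CC1` gives 6400 nM
compound 3 `CC1=CC[C@H](C(C)(C)NC(=S)N/N=C/c2cccc(Cl)c2)CC1` gives 7900 nM

Compound 3 has the second highest of the three numbers: its nearest neighbour is compound 2, with a 1.2-fold higher number from compound 2 to compound 3 (0.09 log units; within the scatter), and its furthest is compound 1, with a 1.4-fold lower number from compound 1 to compound 3 (0.16 log units; within the scatter), both within the scatter. The change to compound 4 `CC1=CC[C@H](C(C)(C)NC(=S)N/N=C/c2ccco2)CC1` is furan-2-yl in place of 3-chlorophenyl on a carbon with a double bond to nitrogen. All three measured steps exchange the aryl group on that same carbon: a 1.8-fold lower number from compound 1 to compound 2 (0.25 log units; within the scatter), a 1.4-fold lower number from compound 1 to compound 3 (0.16 log units; within the scatter) and a 1.2-fold higher number from compound 2 to compound 3 (0.09 log units; within the scatter), none of them beyond the scatter. A further exchange at that position is therefore expected to give no step beyond the scatter in this assay, in either direction. For compound 4 the expected value is 8000 nM, with a range from 3000 nM to 22000 nM. The step this estimate implies is a 1.0-fold higher number from compound 3 to compound 4 (0.01 log units; within the scatter), expected to stay within the scatter.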

Compound 4, concentration for 50% growth inhibition: 9700 nM
Compound 4: the middle estimate sits 1.2-fold (0.08 log units) below what was measured; low and high end bracket the measured number.
By their numbers in this assay, from the lowest: compounds 2, 3, 4 and 1 (each within the scatter of the next).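

Furan-2-yl in this assay extends the exchange at the carbon with a double bond to nitrogen to a five-membered aromatic ring with 1 hetero atom, where the earlier compounds carried only six-membered aromatic rings of carbon. The steps of a 1.2-fold higher number from compound 3 to compound 4 (0.09 log units; within the scatter) and a 1.5-fold higher number from compound 2 to compound 4 (0.18 log units; within the scatter) and also a 1.2-fold lower number from compound 1 to compound 4 (0.07 log units; within the scatter) all lie within the scatter, so this change in ring size leaves the number without a step beyond the scatter.

From the compounds shown here alone, whether an amine or a carboxylic acid in place of the aromatic ring would give a step beyond the scatter remains open. No evidence on the reason for these steps is at hand.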